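Swapping the end group of compound 1

This account rests on a few compounds, and the source may have more. Where it says the series, first, only, none or still open, it means among the compounds named here.

Of the compounds shown here, two have been measured in a physicochemical assay for lipophilicity, read by HPLC (on this read-out higher numbers stand for higher lipophilicity and lower numbers for lower lipophilicity), so far.
- compound 1 `Cc1cc(CCCCCOc2c(C)cc(-c3nnn(C)n3)cc2C)on1` (3.6)
- compound 2 `Cc1cc(CCCOc2c(C)cc(-c3nnn(C)n3)cc2C)on1` (3.2)

Compound 1 stands highest of these two, and compound 2 is its nearest neighbour, with a gap beyond the scatter. Compound 3 `CC(=O)c1ccc(CCCCCOc2c(C)cc(-c3nnn(C)n3)cc2C)o1` has not yet been measured. Its structure differs from that of compound 1 as follows (5-acetylfuran-2-yl in place of 3-methyl-1,2-oxazol-5-yl on a saturated chain carbon, five bonds along the chain from an oxygen on an aromatic ring): 5-acetylfuran-2-yl in place of 3-methyl-1,2-oxazol-5-yl on a saturated chain carbon, five bonds along the chain from an oxygen on an aromatic ring. For the measured compounds named here, the only measured step (a number 0.40 log units lower from compound 1 to compound 2 (beyond the scatter)) is modest, and it keeps the 3-methyl-1,2-oxazol-5-yl and alters the chain. It therefore gives a rough scale for steps in this series but no direction for the new change. Going by the values given here, no measurement yet touches the end group itself, so no step beyond the scatter is expected in this assay (no change at the digits printed from compound 1 to compound 3 (within the scatter)), though the uncertainty is wide. Compound 3 is expected at 3.6 (estimated range 3.1 to 4.1).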

Compound 3, partition coefficient: 3.7
Beside the measured number, compound 3's estimate is 0.10 log units below it, within the range that was stated.
By their numbers in this assay, from the lowest: compound 2; then compounds 1 and 3 (each within the scatter of the next).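

In this assay, for the compounds shown here, the first change to the end group itself gave a number 0.10 log units higher from compound 1 to compound 3 (within the scatter), so at this place, on a saturated chain carbon, five bonds along the chain from an oxygen on an aromatic ring, 5-acetylfuran-2-yl and 3-methyl-1,2-oxazol-5-yl could not be told apart. The exchange was not a small one on paper: 8 heavy atoms replaced 6, the ring went from 2 hetero atoms to 1, and a double bond outside aromatic rings came in, while the count of 2 hydrogen-bond acceptors stayed the same. Among the compounds shown, the only step beyond the scatter is still the chain change, and nothing at hand offers a reason for the result with the end group.

Still open, going by these compounds, is whether the same exchange would also leave the read-out unmoved on the chain of compound 2. Also open, on these data alone, is how the acetyl group and the furan ring each contribute, as they enter together here, and whether an end group of another kind, such as an amine or a carboxylic acid, would shift the number at this place.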